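Chloro in place of hydrogen on the pyrazole series

The compounds below may be only part of what the source reports. "The series", "measured", "known", "first", "only" and "open" are said of these compounds alone.

Measured compounds:
compound 1, `COc1ccc(OC)c(-c2cc(-c3ccc(Cl)cc3)nn2-c2ccc(S(=O)(=O)NC(C)=O)cc2)c1`, 36000 nM
compound 2, `Oc1ccc(O)c(-c2cc(-c3ccccc3)nn2-c2ccccc2)c1`, 77400 nM

Of the compounds shown here, two have been tested in a functional assay on cells (Cancer cell lines, Homo sapiens) for cytotoxicity, read by sulforhodamine B assay, with a stated time of 48 h; on this read-out higher numbers stand for weaker inhibition of growth and lower numbers for stronger inhibition of growth. Compound 1, `COc1ccc(OC)c(-c2cc(-c3ccc(Cl)cc3)nn2-c2ccc(S(=O)(=O)NC(C)=O)cc2)c1`, gives 36000 nM. Compound 2, `Oc1ccc(O)c(-c2cc(-c3ccccc3)nn2-c2ccccc2)c1`, gives 77400 nM. Of the two numbers, compound 2 stands at the highest; its nearest neighbour is compound 1, whose number is lower by an amount beyond the scatter. For the measured compounds named here, the two structures differ in several places at once, so no single step between them is counted, and the pair only shows that compound 1 inhibits growth more strongly than compound 2.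

Compound 3, `Oc1ccc(O)c(-c2cc(-c3ccc(Cl)cc3)nn2-c2ccccc2)c1`, is not yet measured. It differs from compound 2 in one place: chloro in place of hydrogen on an aromatic carbon, on an aromatic carbon of a six-membered aromatic ring of carbon only, para to a large group.

Going by the values given here, with no counted step to lean on, the expectation for this change is modest: a step from compound 2 to compound 3 of a 1.5-fold lower number from compound 2 to compound 3 (0.19 log units; within the scatter) is expected, pointing toward stronger inhibition but possibly within the scatter. Compound 3 is estimated at 50000 nM, within a range from 20000 nM to 120000 nM.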

Compound 3, concentration for total growth inhibition: 16800 nM
For compound 3 the middle estimate is 3.0-fold (0.47 log units) above the measured one, outside the stated range (below it).
By their numbers in this assay, from the lowest: compound 3; then compound 1; then compound 2.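

In this assay, for the compounds shown here, the change from phenyl to 4-chlorophenyl provides the first step in this set that can be read at a single place: a 4.6-fold lower number from compound 2 to compound 3 (0.66 log units; beyond the scatter), a modest step that lies beyond the scatter and points toward stronger inhibition of growth. It shows that this aromatic carbon, para to a large group, responds to substitution: with the rest of compound 2 unchanged, one chlorine atom in place of a hydrogen atom shifts the read-out by more than repeat measurements would. The information available offers no measurement that explains this shift.

The compounds shown leave open whether the step is particular to chloro or whether fluoro, bromo, methyl or an amine on the same aromatic carbon would shift the read-out in the same direction and to a similar extent. They also leave open whether the same change would have a comparable effect with other groups elsewhere on the molecule, since this single step comes from one pair, compound 2 and compound 3.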